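The source may hold more compounds than are shown below. What is called first, only, known or untested is meant among the compounds shown, and "the series" means these compounds.

Measured so far:
- compound 1 `CCc1cccc(NC(=O)N[C@H](C)c2ccccc2)c1`: 97% in an ADME assay on the whole organism with Oryza sativa as the target, tested at 0.1 uM; on this read-out lower numbers stand for a stronger effect and higher numbers for a weaker effect at the one concentration tested
- compound 2 `C[C@@H](NC(=O)Nc1cccc(F)c1)c1ccccc1`: 99% in this assay

Among the compounds with values here, compound 2 sits beside compound 1 on these two numbers; the only step, a number 2 percentage points higher from compound 1 to compound 2 (within the scatter), is within the scatter, so neither is set apart from the other. Compound 3 `C[C@@H](NC(=O)Nc1cccc(Cl)c1)c1ccccc1` differs from compound 2 by chloro in place of fluoro on an aromatic carbon. Within the data shown here, no measured step covers a chloro in place of fluoro; the one step at this aromatic carbon was flat, and no step beyond the scatter is expected in this assay. For compound 3 the expected value is 97%, range 90% to 100%, a step of a number 2 percentage points lower from compound 2 to compound 3 (within the scatter).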

Compound 3, a percentage reported as activity, at one concentration (the size of the read-out at that concentration, not a potency): 97%
Compound 3: middle estimate and measured number agree at the digits printed; low and high end bracket the measured number.
By their numbers in this assay, from the lowest: compounds 1, 3 and 2 (each within the scatter of the next).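

At this aromatic carbon, chloro in place of fluoro gives a number 2 percentage points lower from compound 2 to compound 3 (within the scatter) in this assay and chloro in place of ethyl gives no change at the digits printed from compound 1 to compound 3 (within the scatter) so a third group now reads alike with the first two. Within the data shown here, no step among the three compounds lies beyond the scatter, and the position has now taken a second halogen as well as ethyl. No measured evidence bears on why these numbers stay together.

The compounds shown leave open whether an amine or a carboxylic acid at this aromatic carbon would give a step beyond the scatter. They also leave open how this read-out responds to a change elsewhere on the shared core.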